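Halogen swap on the N-oxide ring of a catechol series

A few compounds are considered here, and "the series" means these few. Any claim that something is new, unique, unknown or untested is made for them only; others in the source may bear on it.

Measured compounds:
compound 1 `Cc1cc(C)[n+]([O-])c(Cl)c1-c1noc(-c2cc(O)c(O)c([N+](=O)[O-])c2)n1` – 13.9%
compound 2 `Cc1ccc(-c2noc(-c3cc(O)c(O)c([N+](=O)[O-])c3)n2)c(Br)[n+]1[O-]` – 33.7%

Among the measured compounds shown here, only two compounds carry numbers in a functional assay on the whole organism (liver, strain Wistar) for inhibition, with Rattus norvegicus as the target, with a stated time of 3 h, at a dose of 3 mg/kg by the oral route; on this read-out higher numbers stand for more inhibition at the one dose given (going by the name of the read-out) and lower numbers for less inhibition. For the measured compounds named here, compound 2 stands highest of the two, and its gap to compound 1 lies beyond the scatter; the two differ in more than one place, so no single step between them is counted.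

Compound 3 `Cc1ccc(-c2noc(-c3cc(O)c(O)c([N+](=O)[O-])c3)n2)c(Cl)[n+]1[O-]` is not yet measured. Its difference from compound 2 is chloro in place of bromo on an aromatic carbon, on an aromatic carbon of a six-membered aromatic ring with 1 nitrogen, the rest of the molecule unchanged.

Going by the values given here, no measured pair shows what this swap does here. In this assay the step from compound 2 to compound 3 is expected to be small and most likely within the scatter, a number 5.7 percentage points lower from compound 2 to compound 3 (within the scatter). Compound 3 is therefore estimated at 28%, with a range from 12% to 45%.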

Compound 3, a percentage reported as inhibition, in the whole organism at one dose (the size of the read-out at that dose, not a potency): 31.6%
The estimate for compound 3 lay 3.6 percentage points below the measured number, within the range that was stated.
By their numbers in this assay, from the lowest: compound 1; then compounds 3 and 2 (each within the scatter of the next).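

In this assay chloro in place of bromo on the aromatic carbon next to the ring nitrogen gives a number 2.1 percentage points lower from compound 2 to compound 3 (within the scatter) and so the two halogens cannot be told apart at this position. Among the compounds shown here, compound 3 also supplies the first comparison that differs in one place from compound 1: hydrogen in place of methyl on an aromatic carbon gives a number 17.7 percentage points higher from compound 1 to compound 3 (beyond the scatter) and so, with chloro held constant, this change alone accompanies a step beyond the scatter. No available measurement accounts for either step.

As far as these compounds go, whether the flat result next to the ring nitrogen extends beyond halogens remains open, for instance to a methoxy group or an amine. Also open, from the compounds shown here alone, is how a longer chain in place of the methyl would compare with hydrogen on that aromatic carbon.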